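Sulfur side chain: carbamoyl to imidazolylmethyl

The source may hold more compounds than are shown below. What is called first, only, known or untested is meant among the compounds shown, and "the series" means these compounds.

In a functional assay on HT cells (Homo sapiens) for antiproliferative activity, read by fluorescence, with a stated time of 72 h (on this read-out higher numbers stand for weaker inhibition of growth and lower numbers for stronger inhibition of growth), compound 1 `CC(C)c1n[nH]c2c(NCc3ccc(-c4ccccn4)cc3)nc(SCCCO)nc12` gives 109 nM and compound 2 `CC(C)c1n[nH]c2c(NCc3ccc(-c4ccccn4)cc3)nc(SCC(N)=O)nc12` gives 192 nM. Going by the values given here, compound 2 therefore stands level with compound 1, the only other measured number. Among the compounds with values here, the sole measured step, a 1.8-fold higher number from compound 1 to compound 2 (0.25 log units; within the scatter), also changes this side chain. Compound 3 `CC(C)c1n[nH]c2c(NCc3ccc(-c4ccccn4)cc3)nc(SCCn3ccnc3)nc12` carries (1H-imidazol-1-yl)methyl in place of carbamoyl on a saturated chain carbon bound to a sulfur. Within the data shown here, no measured compound has an aromatic ring on this chain, so the guidance is thin. The estimated change in this assay is a 1.3-fold lower number from compound 2 to compound 3 (0.11 log units; within the scatter), none beyond the scatter. For compound 3 the expected value is 150 nM, with an estimated range of 50 nM to 450 nM.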

Compound 3, concentration for 50% growth inhibition: 155 nM
Compound 3: the middle estimate sits 1.0-fold (0.01 log units) below what was measured; measured number inside the range.
By their numbers in this assay, from the lowest: compounds 1, 3 and 2 (each within the scatter of the next).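

An aromatic ring on the sulfur side chain is accepted in this assay: (1H-imidazol-1-yl)methyl in place of carbamoyl reads as (a 1.2-fold lower number from compound 2 to compound 3 (0.09 log units; within the scatter)), and 1H-imidazol-1-yl in place of hydroxymethyl reads as (a 1.4-fold higher number from compound 1 to compound 3 (0.15 log units; within the scatter)). The entering group has 0 hydrogen-bond donors where carbamoyl has 1, so among these three compounds a donor on this chain is not required to stay within the scatter. Nothing available explains why these side chains read alike.

Open, on these data alone, is how a primary amine or a carboxylic acid on this chain would read, and whether a longer chain carrying 1H-imidazol-1-yl would stay within the scatter.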